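The source may hold more compounds than are shown below. What is called first, only, known or untested is meant among the compounds shown, and "the series" means these compounds.

Measured in an ADME assay on MRC5 cells (Homo sapiens) for cytotoxicity; on this read-out lower numbers stand for higher toxicity in this test and higher numbers for lower toxicity in this test:
- Compound 1 `Cc1ccc2nc(-c3ccc(NC(=O)NC[C@H]4O[C@H](n5cc(C)c(=O)[nH]c5=O)C[C@@H]4O)cc3)sc2c1` gives > 50000 nM (a limit)
- Compound 2 `Cc1cn([C@@H]2C[C@H](O)[C@@H](CNC(=O)Nc3ccc(-c4ccc(C(F)(F)F)nc4)cc3)O2)c(=O)[nH]c1=O` gives > 50000 nM (a limit)

Compound 1 gives only a limit (> 50000 nM), so its place in the series cannot be ranked. The evidence so far is the limit of > 50000 nM in this assay, at which 2 of the 2 values shown sit.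

Compound 3 (`Cc1cn([C@@H]2C[C@H](O)[C@@H](CNC(=O)Nc3ccc(OCc4ccc(C(C)(C)C)cc4)cc3)O2)c(=O)[nH]c1=O`) is still to be measured. Its change from compound 1 is (4-(tert-butyl)benzyl)oxy in place of 6-methyl-1,3-benzothiazol-2-yl on an aromatic carbon. Among the compounds with values here, the one measured step bearing on it (a step that the two limits leave unreadable from compound 1 to compound 2) replaces the same 6-methyl-1,3-benzothiazol-2-yl on an aromatic carbon, but its size cannot be read.

No step beyond the scatter is therefore expected in this assay, and any readable move from a limit could only go towards lower numbers. The estimated step is a number no higher from compound 1 to compound 3 (the limit leaves the size open) and remains an expectation only. The estimate for compound 3 is 50000 nM with an expected range from 20000 nM to 100000 nM and a good chance of another limit.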

Compound 3, half-maximal cytotoxic concentration: > 50000 nM
Compound 3 gave a limit, no number; the forecaster's own chance of this, stated with the estimate: 70%; the middle value lies on the limit itself.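

Within the data shown here, compound 3 gives > 50000 nM, a limit, so no step from compound 1 or compound 2 to compound 3 can be read in this assay: the limit of > 50000 nM in this assay, at which 3 of the 3 values shown sit. Open, as far as these compounds go, is how these three compounds rank, and whether any group on that aromatic carbon would give a readable number.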